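The source may report more compounds than this note shows. Statements on the series, on what has been measured and on what is new or still open speak of the compounds shown alone.

Compound 2 `CCOC(=O)Nc1nc2ccc(NC(=O)c3c(Cl)cccc3Cl)cc2s1` holds the lower of the two numbers measured in a functional assay on WI-38 VA13 cells (Homo sapiens) for cytotoxicity; a lower number here means that less compound is needed, a higher number that more compound is needed for the effect: compound 2 gives 0.0026 ug/mL, while compound 1 `O=C(Nc1ccc2nc(NC(=O)C3CCCCC3)sc2c1)c1c(Cl)cccc1Cl` gives 0.015 ug/mL. Going by the values given here, the single measured step between them, a 5.8-fold lower number from compound 1 to compound 2 (0.76 log units; beyond the scatter), concerns the group attached to the carbonyl carbon of the shared core. Compound 3 `O=C(Nc1nc2ccc(NC(=O)c3c(Cl)cccc3Cl)cc2s1)Oc1ccccc1` keeps the (ethoxycarbonyl)amino arrangement of compound 2 but alters it by phenyl in place of ethyl on an oxygen next to a carbonyl group, so this change sits on an oxygen next to a carbonyl group rather than on the carbonyl carbon itself. Among the compounds with values here, no measured step touches that oxygen. Within the data shown here, the one step that does exist, from cyclohexyl to ethoxy, shows that this region of the molecule can shift the number beyond the scatter, but it gives no direct guide to swapping ethyl for phenyl. For compound 3 the step of a 1.5-fold higher number from compound 2 to compound 3 (0.19 log units; within the scatter) is therefore expected to be small, with its direction uncertain. Compound 3 is estimated at 0.004 ug/mL in this assay, with a likely range from 0.0012 ug/mL to 0.013 ug/mL.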

Compound 3, half-maximal effective concentration: 1.1 ug/mL
Compound 3: middle estimate off by 280-fold (2.44 log units), on the low side; the measured number lies above the stated range.
By their numbers in this assay, from the lowest: compound 2; then compound 1; then compound 3.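

In this assay the group on an oxygen next to a carbonyl group proves far from neutral, since phenyl in place of ethyl brings a 420-fold higher number from compound 2 to compound 3 (2.63 log units; beyond the scatter) and so turns one of the lowest numbers into the highest of the set. Likewise there is a 73-fold higher number from compound 1 to compound 3 (1.87 log units; beyond the scatter), in the same direction, meaning that much more compound is needed for the cytotoxic effect. A six-membered ring as such does not go with the high number, as compound 1 also carries one at this end of the molecule, a cyclohexyl attached directly to the carbonyl carbon, yet its number stays far lower.

Going by these compounds, what cyclohexyloxy, a longer chain such as butoxy, or a phenyl ring carrying a chlorine would do on this oxygen remains open, so these three compounds cannot separate the part played by the aromatic ring from that of the rest of the change. Nothing among the data shown offers a reason for this jump.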